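Swapping a phenyl for an acetamido on a weak binder

The compounds below may be only part of what the source reports. "The series", "measured", "known", "first", "only" and "open" are said of these compounds alone.

In an assay on CHO-K1 cells for displacement of a labelled ligand from adenosine receptor A1 (Homo sapiens), read by scintillation counting, with a stated time of 60 min (on this read-out higher numbers stand for weaker inhibition and lower numbers for stronger inhibition), three compounds built on the same nucleoside core have been examined. Compound 1 `Nc1nc(N/N=C/c2ccc(N(c3ccccc3)c3ccccc3)cc2)nc2c1ncn2[C@@H]1O[C@H](CO)[C@@H](O)[C@H]1O` reaches only the limit of the assay, giving > 10000 nM. Compound 3 `COc1cc(/C=N/Nc2nc(N)c3ncn([C@@H]4O[C@H](CO)[C@@H](O)[C@H]4O)c3n2)cc(OC)c1OC` likewise stops at the limit, with > 10000 nM. Within the data shown here, compound 2 `Nc1nc(N/N=C/c2ccc(-c3ccccc3)cc2)nc2c1ncn2[C@@H]1O[C@H](CO)[C@@H](O)[C@H]1O` is the one member of the set that returns an actual number, 7860 nM, and so it is the only firm point of reference. Compound 1 and compound 3 both sit at the limit rather than at a number (the limit of > 10000 nM in this assay, at which 2 of the 3 values shown sit).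

Compound 4 `CC(=O)Nc1ccc(/C=N/Nc2nc(N)c3ncn([C@@H]4O[C@H](CO)[C@@H](O)[C@H]4O)c3n2)cc1` is compound 2 altered in one place: acetamido in place of phenyl on an aromatic carbon. Among the measured compounds shown here, no measured pair in this set differs in a single place, so there is no measured step to lean on. Given that compound 2 itself sits near the edge of what this assay can resolve, the step from compound 2 to compound 4 is expected to be small, a 1.0-fold higher number from compound 2 to compound 4 (0.01 log units; within the scatter), perhaps none beyond the usual scatter. Compound 4 is therefore estimated at 8000 nM, with a plausible range from 2000 nM to 30000 nM, and a real chance that only a limit is reported.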

Compound 4, inhibition constant: > 10000 nM
Compound 4: only a limit was reported; the forecaster's own chance of this, stated with the estimate: 50%; at least 1.2-fold (0.09 log units) between middle value and limit.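

In this assay compound 4 gives > 10000 nM, which is a limit of the assay and not a number. Putting acetamido in place of the phenyl ring on this aromatic carbon brings in a hydrogen-bond donor and a hydrogen-bond acceptor, and the swap gives an at least 1.2-fold higher number from compound 2 to compound 4 (0.10 log units; that floor lies within the scatter), so there is no sign of stronger binding, yet no real weakening can be claimed either. This new compound also joins most of the set in giving no firm number: the limit of > 10000 nM in this assay, at which 3 of the 4 values shown sit.

Going by these compounds, how large the true step is remains open, since it could be negligible or much greater than this floor. Also open, on these data alone, is whether an amine or a carboxylic acid on this same aromatic carbon would return a firm number.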